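Fluorine for methoxy on the chalcone aryl ring

The source may report more compounds than this note shows. Statements on the series, on what has been measured and on what is new or still open speak of the compounds shown alone.

Compound 2 `COc1ccc(C(=O)/C=C/c2cc(-c3cc(OC)c(OC)c(OC)c3)n[nH]2)cc1` gives 97% in a functional assay on SW-620 cells (Homo sapiens) for cytotoxicity, read by sulforhodamine B assay, with a stated time of 48 h, tested at 0.1 uM (a lower number here means a stronger effect, a higher number a weaker effect of the compound at the concentration tested), and stands lowest of the two measured numbers, with its neighbour compound 1 `COc1ccc(C(=O)/C=C/c2cc(-c3cc(OC)c(OC)c(OC)c3)n[nH]2)cc1OC` at 99% lying within the scatter of it, a gap of a number 2 percentage points lower from compound 1 to compound 2 (within the scatter). Compound 3 `COc1cc(-c2cc(/C=C/C(=O)c3ccc(F)c(F)c3)[nH]n2)cc(OC)c1OC` is not yet measured; it differs from compound 2 by 3,4-difluorophenyl in place of 4-methoxyphenyl on a carbonyl carbon. Among the measured compounds shown here, no measured step covers an exchange of this kind; the only step known, the loss of a methoxy from compound 1 to compound 2, stayed within the scatter, so no move beyond the scatter is expected in this assay, a step of a number 2 percentage points lower from compound 2 to compound 3 (within the scatter). Compound 3 is therefore estimated at 95%, between 80% and 105%.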

Compound 3, a percentage reported as activity, at one concentration (the size of the read-out at that concentration, not a potency): 97%
Beside the measured number, compound 3's estimate is 2 percentage points below it; low and high end bracket the measured number.
By their numbers in this assay, from the lowest: compounds 2, 3 and 1 (each within the scatter of the next).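

At the carbonyl carbon, 3,4-difluorophenyl in place of 4-methoxyphenyl gives no change at the digits printed from compound 2 to compound 3 (within the scatter) in this assay, and in place of 3,4-dimethoxyphenyl it gives a number 2 percentage points lower from compound 1 to compound 3 (within the scatter). The read-out at this one concentration therefore does not separate an aryl ring carrying methoxy from one carrying only fluorine, which the earlier pair, differing by a single methoxy, could not show. Nothing available explains this result. From the compounds shown here alone, whether an amine or a carboxylic acid on this ring would move the number beyond the scatter stays open, as does whether these compounds would separate at other concentrations.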